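The source may report more compounds than this note shows. Statements on the series, on what has been measured and on what is new or still open speak of the compounds shown alone.

Measured so far in a functional assay on NCI-H460 cells (Homo sapiens) for cytotoxicity, read by MTT assay, with a stated time of 72 h; on this read-out higher numbers stand for weaker inhibition and lower numbers for stronger inhibition:
Compound 1 `CCN(CC)Cc1ccc2nc(NC(=O)N/N=C/c3cn(Cc4ccc(C(C)(C)C)cc4)c4ccccc34)sc2c1`: 1670 nM
Compound 2 `CC1CCN(Cc2ccc3nc(NC(=O)N/N=C/c4cn(Cc5ccc(Cl)cc5Cl)c5ccccc45)sc3c2)CC1`: 1660 nM
Compound 3 `Cc1ccc(Cn2cc(/C=N/NC(=O)Nc3nc4ccc(CN5CCC(C)CC5)cc4s3)c3ccccc32)cc1`: 410 nM

Compound 3 stands lowest of the three at 410 nM, beyond the scatter from both others. The values of compound 1 and compound 2 lie within the scatter of each other.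

Compound 4 `CC1CCN(Cc2ccc3nc(NC(=O)N/N=C/c4cn(Cc5ccc(C(C)(C)C)cc5)c5ccccc45)sc3c2)CC1` has not yet been measured. It departs from compound 3 in one place, 4-methylbenzyl to 4-(tert-butyl)benzyl: tert-butyl in place of methyl on an aromatic carbon.

Among the measured compounds shown here, only one measured step touches this group: a 4.0-fold lower number from compound 2 to compound 3 (0.61 log units; beyond the scatter). That modest step shows that the number in this assay can move with the substituents on this ring, but it does not involve tert-butyl. For the measured compounds named here, compound 1 is the only measured compound with the 4-(tert-butyl)benzyl group, and it gives 1670 nM. Going by the values given here, it also differs from compound 4 elsewhere, so no measured pair isolates this change.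

Among the compounds with values here, the expectation is therefore a rise in the number, no larger than the one measured step and possibly within the scatter. The expected change is a 2.0-fold higher number from compound 3 to compound 4 (0.29 log units; within the scatter). For compound 4 the estimate is 800 nM, with an expected range of 300 nM to 2000 nM.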

Compound 4, half-maximal inhibitory concentration: 3370 nM
Beside the measured number, compound 4's estimate is 4.2-fold (0.62 log units) below it; measured number outside the range, above it.
By their numbers in this assay, from the lowest: compound 3; then compounds 2, 1 and 4 (each within the scatter of the next, the first and the last beyond it).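

Among the compounds shown here, with the 4-methylpiperidin-1-yl end held constant in this assay, the change at this position is isolated for the first time, and tert-butyl in place of methyl on the aromatic carbon gives an 8.2-fold higher number from compound 3 to compound 4 (0.91 log units; beyond the scatter); this shows that the group at this position can by itself shift the number beyond the scatter. Among the groups on the saturated chain carbon, the 4-(tert-butyl)phenyl group in place of 2,4-dichlorophenyl gives a 2.0-fold higher number from compound 2 to compound 4 (0.31 log units; beyond the scatter), so that exchange is also readable, while the 4-methylphenyl group of compound 3 remains the only one giving a number beyond the scatter from all three others. With 4-(tert-butyl)benzyl held, 4-methylpiperidin-1-yl in place of diethylamino gives a 2.0-fold higher number from compound 1 to compound 4 (0.30 log units; within the scatter), so these two amine ends cannot be told apart in this pair, and no available evidence explains any of these steps.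

From the compounds shown here alone, whether ethyl or isopropyl at this position would give a number nearer that of compound 3 or that of compound 4 remains open. Also open, going by these compounds, are whether the step from methyl to tert-butyl carries over to a diethylamino compound, and how a morpholine end would compare with 4-methylpiperidin-1-yl.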